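Methyl for hydrogen on the ring amine chain carbon

The compounds below may be only part of what the source reports. "The series", "measured", "known", "first", "only" and "open" are said of these compounds alone.

Values in a functional assay on Jurkat cells (Homo sapiens) for inhibition, read by CCK-8 assay, with a stated time of 48 h; on this read-out higher numbers stand for weaker inhibition of growth and lower numbers for stronger inhibition of growth:
compound 1 `Cc1ccccc1Nc1nc(Nc2ccc(N3CCN(C)CC3)cn2)ncc1Cl` gives 8080 nM
compound 2 `CCN1CCN(c2ccc(Nc3ncc(Cl)c(Nc4ccccc4C)n3)nc2)CC1` gives > 100000 nM, a limit of the assay and not a number
compound 3 `Cc1ccccc1Nc1nc(Nc2ccc(N3CCN(C)CC3)cc2)ncc1Cl` gives 13700 nM

Compound 1 and compound 2 differ in one place (methyl in place of hydrogen on a saturated chain carbon bound to an amine nitrogen in a ring). The step is an at least 12-fold higher number from compound 1 to compound 2 (1.09 log units; beyond the scatter). Compound 2 sits at the limit of > 100000 nM in this assay, at which 1 of the 3 values shown sits, so the true size of that step is open at the upper end.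

Compound 3 shares the change-bearing part with compound 1, but the difference between the two cores is not broken down here. In this assay compound 3 and compound 1 give numbers that lie within the scatter of each other, so no order between them is claimed.

Compound 4 `CCN1CCN(c2ccc(Nc3ncc(Cl)c(Nc4ccccc4C)n3)cc2)CC1` is not yet measured. It differs from compound 3 by methyl in place of hydrogen on a saturated chain carbon bound to an amine nitrogen in a ring. The place line reads the same as for the pair compound 1 to compound 2, so this is the same change on the core of compound 3.

Going by the values given here, only one measured instance of the change exists, and in it compound 2 runs into the assay limit. The expectation for compound 4 rests on an at least 12-fold higher number from compound 1 to compound 2 (1.09 log units; beyond the scatter) and on the starting value of compound 3, 13700 nM. The step from compound 3 to compound 4 is expected to be a 12-fold higher number from compound 3 to compound 4 (1.07 log units; beyond the scatter), of the same sign and at least as large as the earlier one. Compound 4 is therefore estimated at 160000 nM, with a range from 40000 nM to 600000 nM, and the measurement is expected more often than not to come back as a limit rather than a number.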

Compound 4, concentration for 50% growth inhibition: 2060 nM
The estimate for compound 4 lay 78-fold (1.89 log units) above the measured number; the whole stated range lies above it.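

In this assay, going from 4-methylpiperazin-1-yl to 4-ethylpiperazin-1-yl gives a 6.7-fold lower number from compound 3 to compound 4 (0.82 log units; beyond the scatter), so the change does not carry over from one core to the other, and the two steps run in opposite directions: the same change on two cores in this assay, an at least 12-fold higher number (1.09 log units; beyond the scatter) from compound 1 to compound 2 and a 6.7-fold lower number (0.82 log units; beyond the scatter) from compound 3 to compound 4, at least 82-fold (1.91 log units) apart, beyond the scatter of two such steps

The earlier step has compound 2 at one end, and what stands there is a limit of the assay and not a number: the limit of > 100000 nM in this assay, at which 1 of the 4 values shown sits.

Going by these compounds alone, compound 1 and compound 3 lie within the scatter of each other, so their values give no sign of this split; with only two pairs, the notes can say that the step from methyl to ethyl on this amine ring depends on the core, but not which feature of the cores is responsible or how a third core would respond.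

Open, as far as these compounds go, is whether a longer chain such as n-propyl, or a cyclopropyl ring or 2-hydroxyethyl, in place of the ethyl follows the course seen on the core of compound 3 or that seen on the core of compound 1. Also open, from the compounds shown here alone, is whether the opposite steps persist in growth assays on other cell lines.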